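Trifluoromethyl to methoxy in a growth-inhibition series

The compounds below may be only part of what the source reports. "The series", "measured", "known", "first", "only" and "open" are said of these compounds alone.

Measured in a functional assay on A549 cells (Homo sapiens) for inhibition, read by CCK-8 assay, with a stated time of 72 h, tested at 10 uM; a higher number here means more inhibition of growth at the concentration tested, a lower number less inhibition of growth:
Compound 1 `CN(C)C(=O)c1cc2cnc(Nc3ccc(NC(=O)C4(C(=O)Nc5ccc(Cl)cc5)CC4)cc3)nc2n1C1CCCC1`: 101%
Compound 2 `CN(C)C(=O)c1cc2cnc(Nc3ccc(NC(=O)C4(C(=O)Nc5cccc(C(F)(F)F)c5)CC4)cc3)nc2n1C1CCCC1`: 89.2%

Of the two measured compounds, compound 2 stands lower in this assay, at 89.2%. Compound 3 `COc1cccc(NC(=O)C2(C(=O)Nc3ccc(Nc4ncc5cc(C(=O)N(C)C)n(C6CCCC6)c5n4)cc3)CC2)c1` differs from it by methoxy in place of trifluoromethyl on an aromatic carbon. Among the compounds with values here, only one measured step bears on this, the modest a number 11.8 percentage points lower from compound 1 to compound 2 (beyond the scatter), which also exchanged the substituted phenyl on the amide-type nitrogen. With so little evidence, no clear direction can be drawn from it, and no shift beyond the scatter is expected. The expected change is a number 1.8 percentage points higher from compound 2 to compound 3 (within the scatter). For compound 3 the estimate is 91%, with an expected range of 76% to 103%.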

Compound 3, percent growth inhibition at one concentration: 96%
For compound 3 the middle estimate is 5 percentage points below the measured one; measured number inside the range.
By their numbers in this assay, from the lowest: compounds 2, 3 and 1 (each within the scatter of the next, the first and the last beyond it).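

In this assay, methoxy in place of trifluoromethyl on this aromatic carbon gives a number 6.8 percentage points higher from compound 2 to compound 3 (within the scatter), so this exchange, unlike the earlier step, stays within the scatter. The step of a number 5 percentage points lower from compound 1 to compound 3 (within the scatter), with 3-methoxyphenyl in place of 4-chlorophenyl, also stays within it, whereas 3-(trifluoromethyl)phenyl in the same place did not. No measurement shown here accounts for these numbers. As far as these compounds go, it remains open whether an amine or a carboxylic acid on this aromatic carbon would also leave the number within the scatter of compound 3.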